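A few compounds are considered here, and "the series" means these few. Any claim that something is new, unique, unknown or untested is made for them only; others in the source may bear on it.

Compound 1 `CCCn1c(=O)c2nc([C@@H]3CC4C=CC3C4)[nH]c2n(CCC)c1=O` gives 4.3 nM in an assay on cell membranes for binding affinity to adenosine receptor A1 (Cavia porcellus), read by radioligand binding; a lower number here means a stronger inhibitor, a higher number a weaker inhibitor.
Compound 2 `CCCn1c(=O)c2nc(C(C)(C)C)[nH]c2n(CCC)c1=O` gives 31 nM in this assay.

Going by the values given here, of these two numbers, compound 2 stands highest; its only neighbour is compound 1, separated by the step of a 7.2-fold higher number from compound 1 to compound 2 (0.86 log units; beyond the scatter). Compound 3 `CCCn1c(=O)c2nc(CC3CC3)[nH]c2n(CCC)c1=O` has not yet been measured. It differs from compound 2 by cyclopropylmethyl in place of tert-butyl on an aromatic carbon. Among the compounds with values here, the single measured step bears on this only loosely: there, a ring-containing group gave way to tert-butyl and the number rose. In compound 3 a ring comes back, though a far smaller one than in compound 1, so the step of a 1.6-fold lower number from compound 2 to compound 3 (0.19 log units; within the scatter) is expected to be small, more likely toward a lower number, and possibly not reaching beyond the scatter. For compound 3 the estimate in this assay is 20 nM, with a range from 6 nM to 70 nM.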

Compound 3, inhibition constant: 120 nM
For compound 3 the middle estimate is 6.0-fold (0.78 log units) below the measured one; the measured number lies above the stated range.
By their numbers in this assay, from the lowest: compound 1; then compound 2; then compound 3.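

Replacing tert-butyl with cyclopropylmethyl leaves the heavy-atom count of the group on this aromatic carbon unchanged, yet this assay shows a 3.9-fold higher number from compound 2 to compound 3 (0.59 log units; beyond the scatter) for this swap. A ring in the group is therefore not enough on its own to give a lower number here, and groups of equal heavy-atom count can differ beyond the scatter. The two-ring group of compound 1 stands well apart from this small ring, with a 28-fold higher number from compound 1 to compound 3 (1.45 log units; beyond the scatter) in the same assay, although nothing available explains either step.

Still open, going by these compounds, is whether a cyclopropyl group joined directly to the aromatic carbon would behave like cyclopropylmethyl. It is also unclear whether a single larger ring, such as cyclopentyl or cyclohexyl, would bring the number closer to that of compound 1.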